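Chain-End Ring Exchange: From Carbamoyl Triazole to Dioxoimidazolidine

The source may report more compounds than this note shows. Statements on the series, on what has been measured and on what is new or still open speak of the compounds shown alone.

Three compounds share one core and differ only in the group at the end of the chain. Compound 1 `CCO/C(O)=C1\C(COCCn2nncc2C(N)=O)=NC(C)=C(C(=O)OC)C1c1ccccc1Cl` gives 100 nM in a functional assay (aorta) with Rattus norvegicus as the target (a lower number here means a stronger inhibitor, a higher number a weaker inhibitor), the highest number of the three. Compound 2 `CCOC(=O)c1cn(CCOCC2=NC(C)=C(C(=O)OC)C(c3ccccc3Cl)/C2=C(\O)OCC)nn1` gives 50.1 nM, and compound 3 `CCO/C(O)=C1\C(COCCn2ccnc2C)=NC(C)=C(C(=O)OC)C1c1ccccc1Cl` gives 2.51 nM. The step of a 2.0-fold lower number from compound 1 to compound 2 (0.30 log units; within the scatter) shows that exchanging the substituent on the triazole barely moves the number, whereas a 40-fold lower number from compound 1 to compound 3 (1.60 log units; beyond the scatter) and a 20-fold lower number from compound 2 to compound 3 (1.30 log units; beyond the scatter) show that the 2-methyl-1H-imidazol-1-yl group brings a large gain.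

Compound 4 `CCO/C(O)=C1\C(COCCN2CC(=O)N(C)C2=O)=NC(C)=C(C(=O)OC)C1c1ccccc1Cl` has not yet been measured in this assay. It differs from compound 1 in one place: 3-methyl-2,4-dioxoimidazolidin-1-yl in place of 5-carbamoyl-1H-1,2,3-triazol-1-yl on a saturated chain carbon, two bonds along the chain from an oxygen on a saturated carbon. For the measured compounds named here, no measured step covers this exchange directly. The step of a 2.0-fold lower number from compound 1 to compound 2 (0.30 log units; within the scatter) is the nearest guide: there too the 5-carbamoyl-1H-1,2,3-triazol-1-yl group gave way to another ring bearing a carbonyl group, and the number stayed within the scatter. The large gain seen with compound 3 came with a ring of another kind. The account therefore expects a step of a 1.6-fold lower number from compound 1 to compound 4 (0.20 log units; within the scatter), modest and not clearly beyond the scatter. Compound 4 is estimated at 63 nM, with a range from 16 nM to 250 nM.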

Compound 4, half-maximal inhibitory concentration: 25.1 nM
For compound 4 the middle estimate is 2.5-fold (0.40 log units) above the measured one; the measured number falls inside the stated range.
By their numbers in this assay, from the lowest: compound 3; then compounds 4, 2 and 1 (each within the scatter of the next, the first and the last beyond it).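

The exchange gives a 4.0-fold lower number from compound 1 to compound 4 (0.60 log units; beyond the scatter) in this assay and shows that a five-membered non-aromatic ring, the 3-methyl-2,4-dioxoimidazolidin-1-yl group, is tolerated on this saturated chain carbon and can carry the number beyond the scatter, which the step to the 4-(ethoxycarbonyl)-1H-1,2,3-triazol-1-yl group had not done. The two carbonyl-bearing replacements themselves stay close together, with a 2.0-fold lower number from compound 2 to compound 4 (0.30 log units; within the scatter) as the printed step, so the data do not separate the dioxoimidazolidine from that triazole. The 2-methyl-1H-imidazol-1-yl group keeps its place at the low end of the series, as the step of a 10-fold higher number from compound 3 to compound 4 (1.00 log units; beyond the scatter) shows, and compound 3 now stands beyond the scatter from all three other compounds.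

Nothing measured here accounts for these differences among the chain-end rings. Still open, on these data alone, are how the unsubstituted 1H-imidazol-1-yl ring, a simple dimethylamino group or a carboxylic acid would read at this chain end, and whether a propyl chain in place of the ethyl link would preserve the number of compound 3.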